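The source may report more compounds than this note shows. Statements on the series, on what has been measured and on what is new or still open speak of the compounds shown alone.

Measured so far, in a functional assay (lung) for inhibition, with Cavia porcellus as the target; on this read-out higher numbers stand for weaker inhibition and lower numbers for stronger inhibition: compound 1 `O=C(O)CC1CCCC1Cc1ccc(OCc2ccc3ccccc3n2)cc1` gives 90 nM; compound 2 `CC(CCCC(=O)O)c1cccc(OCc2ccc3ccccc3n2)c1` gives 500 nM; compound 3 `CC(CCCc1nnn[nH]1)c1cccc(OCc2ccc3ccccc3n2)c1` gives 250 nM.

Compound 1 stands lowest of the three; the difference between its core and the core of compound 2 is not broken down here. Compound 2 and compound 3 share a core and differ by 1H-tetrazol-5-yl in place of carboxy on a saturated chain carbon, four bonds along the chain from an aromatic carbon, which made the step of a 2.0-fold lower number from compound 2 to compound 3 (0.30 log units; within the scatter).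

Compound 4 `c1ccc2nc(COc3ccc(CC4CCCC4Cc4nnn[nH]4)cc3)ccc2c1` is not yet measured. It carries the same kind of change on compound 1, (1H-tetrazol-5-yl in place of carboxy on a saturated chain carbon bound to a saturated ring carbon). The place is not the same: in compound 3 the carbon is four bonds along the chain from an aromatic carbon, in compound 4 it is bound to a saturated ring carbon.

For compound 4 a step of a 1.5-fold lower number from compound 1 to compound 4 (0.18 log units; within the scatter) is expected because a 2.0-fold lower number from compound 2 to compound 3 (0.30 log units; within the scatter) lay within the scatter. Compound 4 is estimated at 60 nM, between 25 nM and 160 nM.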

Compound 4, half-maximal inhibitory concentration: 20 nM
Beside the measured number, compound 4's estimate is 3.0-fold (0.48 log units) above it; the whole stated range lies above it.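

In this assay, 1H-tetrazol-5-yl in place of carboxy on a saturated chain carbon bound to a saturated ring carbon gives a 4.5-fold lower number from compound 1 to compound 4 (0.65 log units; beyond the scatter). The two steps for this change cannot be told apart: the same change on two cores in this assay, a 2.0-fold lower number (0.30 log units; within the scatter) from compound 2 to compound 3 and a 4.5-fold lower number (0.65 log units; beyond the scatter) from compound 1 to compound 4, 2.3-fold (0.35 log units) apart, within the scatter of two such steps. Within the data shown here, this fits a change that carries from one core to the other, but two cores in one read-out do not fix its size, the place of the change differs between them, and only the step on the core of compound 1 stands clear of the scatter.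

Open, as far as these compounds go, is how an acylsulfonamide in place of the 1H-tetrazol-5-yl would read on the core of compound 1. Also open, from the compounds shown here alone, is how a longer chain carrying the 1H-tetrazol-5-yl would read on that core.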